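Dimethoxyphenyl exchange on the chloro member of the series

A few compounds are considered here, and "the series" means these few. Any claim that something is new, unique, unknown or untested is made for them only; others in the source may bear on it.

Values in a functional assay on PC-3 cells (Homo sapiens) for cytotoxicity, read by MTT assay, with a stated time of 48 h; a higher number here means a weaker inhibitor, a lower number a stronger inhibitor:
- compound 1 `COc1ccc(/C=C/C(=O)/C=C/c2cc3ccccc3nc2Oc2ccccc2)c(OC)c1`: > 10000 nM
- compound 2 `COc1ccc(/C=C/C(=O)/C=C/c2cc3ccccc3nc2Oc2ccccc2)cc1OC`: > 10000 nM
- compound 3 `COc1ccc(/C=C/C(=O)/C=C/c2cc3ccccc3nc2Oc2cccc(Cl)c2)c(OC)c1`: > 10000 nM

Each of these values is a limit and not a number. Within the data shown here, the series so far shows (the limit of > 10000 nM in this assay, at which 3 of the 3 values shown sit). Compound 3 stands at > 10000 nM, which is a limit. Compound 4 `COc1ccc(/C=C/C(=O)/C=C/c2cc3ccccc3nc2Oc2cccc(Cl)c2)cc1OC` differs from it by 3,4-dimethoxyphenyl in place of 2,4-dimethoxyphenyl on a double-bonded chain carbon bound to a double-bonded chain carbon, that is, 3,4-dimethoxyphenyl in place of 2,4-dimethoxyphenyl. The same exchange without the chloro is a step that the two limits leave unreadable from compound 1 to compound 2. The chloro change itself is a step that the two limits leave unreadable from compound 1 to compound 3. Among the measured compounds shown here, neither gives a size to carry over, so no step of definite size or direction is expected in this assay, and a further limit is the likeliest report. The expected change is a step that the limit leaves unreadable from compound 3 to compound 4. For compound 4 the estimate is 12000 nM, with an expected range of 5000 nM to 30000 nM.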

Compound 4, half-maximal inhibitory concentration: > 10000 nM
Compound 4 ended at the assay's limit (the forecaster's own chance of this, stated with the estimate: 85%); the middle value is on the limit's open side.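

In this assay compound 4 gives > 10000 nM, which is a limit of the assay, so the steps to compound 4 from compound 3 and from compound 2 cannot be read. The compounds shown leave open whether the 3,4-dimethoxyphenyl exchange or the chloro changes potency at all in this assay: the limit of > 10000 nM in this assay, at which 4 of the 4 values shown sit.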